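The compounds below may be only part of what the source reports. "The series", "measured", "known", "first", "only" and "open" are said of these compounds alone.

Compound 1 `C[C@H](Nc1nc(N)nc(N)c1C#N)c1cc2ccc(F)cn2c(=O)c1-c1ccccc1` and compound 2 `C[C@H](Nc1nc(N)nc(N)c1C#N)c1c(-c2ccccc2)c(=O)n2cc(F)ccc2c1C1CC1` share one core and differ only at a single aromatic carbon. In an ADME assay on the whole organism (Mus musculus, strain BALB/C) for pharmacokinetics, read by LC-MS, with a stated time of 24 h, at a dose of 1 mg/kg by the intravenous route (a lower number here means slower removal, a higher number faster removal of the compound), compound 1 gives 25 mL/min/kg, and compound 2 gives 24 mL/min/kg. Putting a cyclopropyl group in place of hydrogen gave a 1.0-fold lower number from compound 1 to compound 2 (0.02 log units; within the scatter), so on these two numbers compound 2 sits together with compound 1 and neither can be told apart from the other.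

Compound 3 `C[C@H](Nc1nc(N)nc(N)c1C#N)c1c(-c2ccccc2)c(=O)n2cc(F)ccc2c1-c1ccc(F)cc1` changes the same aromatic carbon once more: 4-fluorophenyl in place of cyclopropyl on an aromatic carbon. Among the compounds with values here, the only measured step that touches this position is the one from compound 1 to compound 2, and it stayed within the scatter, so there is no evidence yet that a larger group at this carbon moves the clearance. Within the data shown here, no measured step covers a 4-fluorophenyl group at all, which leaves the direction open. The expectation for compound 3 is therefore a step of about no change at the digits printed from compound 2 to compound 3 (within the scatter) in this assay, no larger than the scatter, in either direction. Compound 3 is estimated at 24 mL/min/kg, with a range from 12 mL/min/kg to 48 mL/min/kg.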

Compound 3, clearance: 5.6 mL/min/kg
Estimate against measurement, compound 3: 4.3-fold (0.63 log units) above; the whole stated range lies above it.
By their numbers in this assay, from the lowest: compound 3; then compounds 2 and 1 (each within the scatter of the next).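

This aromatic carbon is not indifferent to what sits on it in this assay: 4-fluorophenyl in place of cyclopropyl gives a 4.3-fold lower number from compound 2 to compound 3 (0.63 log units; beyond the scatter), and 4-fluorophenyl in place of hydrogen gives a 4.5-fold lower number from compound 1 to compound 3 (0.65 log units; beyond the scatter). The earlier step, with cyclopropyl in place of hydrogen, gave a 1.0-fold lower number from compound 1 to compound 2 (0.02 log units; within the scatter), so filling this position does not by itself shift the clearance, and among the three compounds the outcome depends on which group is put there. The data shown offer no measurement that explains why the 4-fluorophenyl compound stands apart.

The compounds shown leave open whether this lower number goes with the six-membered aromatic ring or with its fluorine, a question that a plain phenyl group on this carbon would help to settle. From the compounds shown here alone, it also remains open how a group of a quite different kind at this position, such as an amine or a carboxylic acid, would compare with the hydrogen, cyclopropyl and 4-fluorophenyl compounds.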